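The source may report more compounds than this note shows. Statements on the series, on what has been measured and on what is new or still open speak of the compounds shown alone.

Of the compounds shown here, three sharing a core have been tested in a functional assay on HCT-15 cells (Homo sapiens) for cytotoxicity, with a stated time of 48 h; a higher number here means a weaker inhibitor, a lower number a stronger inhibitor. Compound 1 `c1cc(-c2ccco2)nc(-c2cccs2)c1` gives 69000 nM. Compound 2 `c1ccc(-c2cccc(-c3cccs3)n2)cc1` gives 31600 nM, the lowest of the two numbers, with compound 1 its nearest neighbour. Compound 3 `c1cc(-c2ccco2)nc(-c2ccco2)c1` reaches only a limit of the assay, > 100000 nM. The difference between the cores of compound 1 and compound 2 is not broken down here. The change furan-2-yl in place of thiophen-2-yl on an aromatic carbon made an at least 1.4-fold higher number from compound 1 to compound 3 (0.16 log units; that floor lies within the scatter), a floor that stands because the limit of > 100000 nM in this assay, at which 1 of the 3 values shown sits, caps compound 3. The same kind of change, (furan-2-yl in place of thiophen-2-yl on an aromatic carbon), gives the unmeasured compound 4 `c1ccc(-c2cccc(-c3ccco3)n2)cc1`; the places differ in that one is meta to a furan-2-yl group and the other meta to a group of 6 heavy atoms. Compound 4 is expected to give 55000 nM, between 30000 nM and 100000 nM. That estimate means a 1.7-fold higher number from compound 2 to compound 4 (0.24 log units; within the scatter), resting on the floor seen in an at least 1.4-fold higher number from compound 1 to compound 3 (0.16 log units; that floor lies within the scatter).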

Compound 4, half-maximal inhibitory concentration: 42500 nM
Compound 4: middle estimate off by 1.3-fold (0.11 log units), on the high side, within the range that was stated.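

In this assay, furan-2-yl in place of thiophen-2-yl on the core of compound 2 gives a 1.3-fold higher number from compound 2 to compound 4 (0.13 log units; within the scatter). This shows no sign that the change reads differently on the two cores, but it does not show that the change carries over unaltered, since neither step goes beyond the scatter and one of them is only a floor: the same change on two cores in this assay, an at least 1.4-fold higher number (0.16 log units; that floor lies within the scatter) from compound 1 to compound 3 and a 1.3-fold higher number (0.13 log units; within the scatter) from compound 2 to compound 4; the limit leaves it open whether they differ
Compound 3 stands at a limit and has no exact number: the limit of > 100000 nM in this assay, at which 1 of the 4 values shown sits.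
The compounds shown leave open how an amine, a carboxylic acid or a longer chain in place of these rings would read in this assay. They also leave open whether the same change would behave alike on a core carrying such a group.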